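The source may report more compounds than this note shows. Statements on the series, on what has been measured and on what is new or still open speak of the compounds shown alone.

Of the compounds shown here, two have so far been measured in an assay for inhibition of Amine oxidase [flavin-containing] B (Bos taurus), read by fluorescence, with a stated time of 60 min; on this read-out lower numbers stand for stronger inhibition and higher numbers for weaker inhibition. Compound 1 `O=C(NNc1nc2ccccc2nc1Cc1ccccc1)c1ccccc1` gives 360000 nM. Compound 2 `O=C(Cn1c(=O)c(Cc2ccccc2)nc2ccccc21)NNC(=O)c1ccc(Cl)cc1` gives 880000 nM, the higher of the two numbers; its nearest neighbour is compound 1, whose number is lower by an amount beyond the usual scatter. Compound 3 `O=C(Cn1c(=O)c(Cc2ccccc2)nc2ccccc21)N/N=C/c1ccc([N+](=O)[O-])cc1` differs from compound 2 in one place: a group of 11 heavy atoms (7 carbon, 2 nitrogen, 2 oxygen; one six-membered aromatic ring of carbon only) in place of a group of 10 heavy atoms (7 carbon, 1 nitrogen, 1 oxygen, 1 chlorine; one six-membered aromatic ring of carbon only), on an amide-type nitrogen. For the measured compounds named here, no step between measured compounds resembles this change, so the size of the move in this assay is uncertain; a modest shift towards a lower number is expected, though none beyond the scatter would not surprise. For compound 3 the estimate is 400000 nM, within 100000 nM to 1500000 nM. The expected step is a 2.2-fold lower number from compound 2 to compound 3 (0.34 log units; beyond the scatter).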

Compound 3, half-maximal inhibitory concentration: 84000 nM
For compound 3 the middle estimate is 4.8-fold (0.68 log units) above the measured one; the whole stated range lies above it.
By their numbers in this assay, from the lowest: compound 3; then compound 1; then compound 2.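

On an amide-type nitrogen, swapping the ((4-chlorophenyl)carbonyl)amino group for the entering group gives a 10-fold lower number from compound 2 to compound 3 (1.02 log units; beyond the scatter) in this assay, so the group held there can move this read-out substantially. The entering group has fewer hydrogen-bond donors and more acceptors than the one it replaces, but its ring substituent and linking atoms also differ, so no single feature can be singled out. No measurement shown here accounts for the step. The compounds shown do not separate the ring substituent from the link, and they leave open how a methoxy group or an amine on that aromatic ring would read.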